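This account rests on a few compounds, and the source may have more. Where it says the series, first, only, none or still open, it means among the compounds named here.

In an assay on isolated protein for displacement of a labelled ligand from metabotropic glutamate receptor 5 (Homo sapiens), with a stated time of 60 min, tested at 1 uM (on this read-out higher numbers stand for more inhibition at the one concentration tested (going by the name of the read-out) and lower numbers for less inhibition), compound 1 `CC1CCN(c2c(S(=O)(=O)c3ccc(F)c(Cl)c3)cnc3cc(F)ccc23)CC1` gives 94%. Compound 2 `CC1CCN(c2c(S(=O)(=O)c3ccc(C#N)cc3)cnc3cc(F)ccc23)CC1` gives 83% in this assay. Compound 3 `CC1CCN(c2c(S(=O)(=O)c3ccc(C#N)cc3)cnc3ccc(F)cc23)CC1` has a core that differs from that of compound 2 in a way that is not broken down here, and compound 3 gives 75%, the lowest of the three numbers. Compound 4 `CC1CCN(c2c(S(=O)(=O)c3ccc(F)c(Cl)c3)cnc3ccc(F)cc23)CC1` has not yet been measured in this assay. It differs from compound 3 by 3-chloro-4-fluorophenyl in place of 4-cyanophenyl on a sulfonyl sulfur, which is the same change that separates compound 1 from compound 2, where 3-chloro-4-fluorophenyl in place of 4-cyanophenyl on a sulfonyl sulfur brought a number 11 percentage points higher from compound 2 to compound 1 (beyond the scatter). Among the compounds shown this change occurs two times in all, once measured and once still open. Going by the values given here, because the measured step of a number 11 percentage points higher from compound 2 to compound 1 (beyond the scatter) was modest and beyond the scatter, the expected step is a number 11 percentage points higher from compound 3 to compound 4 (beyond the scatter), resting on the single earlier instance of the change and on the value of compound 3 of 75%. Compound 4 is accordingly estimated at 86% in this assay, with a likely range from 76% to 94%.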

Compound 4, a percentage reported as inhibition, at one concentration (the size of the read-out at that concentration, not a potency): 95%
Compound 4: the middle estimate sits 9 percentage points below what was measured; measured number above the stated range.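

In this assay, 3-chloro-4-fluorophenyl in place of 4-cyanophenyl on a sulfonyl sulfur again brought a number 20 percentage points higher from compound 3 to compound 4 (beyond the scatter). Set beside the earlier instance, the change carried over from one core to the other in direction, and the two steps do not separate in size: the same change on two cores in this assay, a number 11 percentage points higher (beyond the scatter) from compound 2 to compound 1 and a number 20 percentage points higher (beyond the scatter) from compound 3 to compound 4, 9 percentage points apart, within the scatter of two such steps. Going by these compounds alone, this rests on only two cores and a single pair of groups, read at one concentration, and it does not show that the step would hold on any other core or that potency would shift to a similar degree.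

The compounds shown leave open how other groups on the sulfonyl sulfur would read, such as a longer alkyl chain or a phenyl ring carrying a carboxylic acid. They also leave open whether the change would behave the same way if an amine other than the one shared by all four compounds stood on the core.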